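The compounds below may be only part of what the source reports. "The series", "measured", "known", "first", "only" and "open" are said of these compounds alone.

Measured in a functional assay on HOP-62 cells (Homo sapiens) for inhibition, read by sulforhodamine B assay; on this read-out lower numbers stand for stronger inhibition of growth and higher numbers for weaker inhibition of growth:
- compound 1 `FC(F)(F)c1ccc(-c2ccc(-c3ccc(-c4nc5ccccc5[nH]4)cc3)cc2)cc1`: 100000 nM
- compound 2 `Oc1cccc2[nH]c(-c3ccc(-c4ccc(-c5ccc(F)cc5)cc4)cc3)nc12`: 8310 nM

Compound 2 holds the lower of the two numbers, and the gap to compound 1 lies beyond the scatter. Compound 3 `Oc1cccc2[nH]c(-c3ccc(-c4ccc(-c5ccc(C(F)(F)F)cc5)cc4)cc3)nc12` departs from compound 2 in one place: trifluoromethyl in place of fluoro on an aromatic carbon, para to a large group. Within the data shown here, no measured pair isolates this change, so the expectation rests on little. The expected 1.6-fold higher number from compound 2 to compound 3 (0.19 log units; within the scatter) in this assay is small, with none beyond the scatter, though the range leans toward weaker inhibition of growth. Compound 3 is estimated at 13000 nM, with an expected range of 5000 nM to 40000 nM.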

Compound 3, concentration for 50% growth inhibition: 3200 nM
Compound 3: middle estimate off by 4.1-fold (0.61 log units), on the high side; measured number below the stated range.
By their numbers in this assay, from the lowest: compound 3; then compound 2; then compound 1.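

In this assay, trifluoromethyl in place of fluoro on this aromatic carbon, para to a large group, gives a 2.6-fold lower number from compound 2 to compound 3 (0.41 log units; beyond the scatter) and so shows that this position responds to the change, toward stronger inhibition of growth. Hydroxy in place of hydrogen on an aromatic carbon gives a 31-fold lower number from compound 1 to compound 3 (1.49 log units; beyond the scatter) as the first single-place reading of that change. No evidence bears on the cause of either step.

Still open, from the compounds shown here alone, is whether a nitrile or a methoxy group on the same carbon moves the number further. Also open, going by these compounds, is whether an amine can stand in place of the hydroxy.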